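Swapping the Triazole Nitrogen Substituent: From Dimethoxyphenyl to Ethylbenzyl

This account rests on a few compounds, and the source may have more. Where it says the series, first, only, none or still open, it means among the compounds named here.

This set of compounds was tested in an in vitro assay on LLC-PK1 cells for displacement of a labelled ligand from growth hormone secretagogue receptor type 1 (Homo sapiens); on this read-out higher numbers stand for weaker inhibition and lower numbers for stronger inhibition. Compound 1 `CCc1ccc(Cn2c(CCc3ccccc3)nnc2[C@H](NC(=O)c2ccccn2)c2c[nH]c3ccccc23)cc1` gives 67 nM. Compound 2 `CCc1ccc(Cn2c(CCc3ccccc3)nnc2[C@H](NC(=O)c2ccncc2)c2c[nH]c3ccccc23)cc1` differs from it only in the position of the ring nitrogen in the pyridine attached to the carbonyl carbon; for compound 2 the assay reports only a limit, > 1000 nM. Among the measured compounds shown here, that single change, an at least 14-fold higher number from compound 1 to compound 2 (1.17 log units; beyond the scatter), is a large loss of binding, and it is the only measured step in this set. Compound 3 `COc1ccc(-n2c(CCc3ccccc3)nnc2[C@H](NC(=O)Cc2ccccn2)c2c[nH]c3ccccc23)c(OC)c1` gives 120 nM; this number and that of compound 1 lie within the usual scatter of each other, so neither can be called the stronger binder.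

Compound 4 `CCc1ccc(Cn2c(CCc3ccccc3)nnc2[C@H](NC(=O)Cc2ccccn2)c2c[nH]c3ccccc23)cc1` has not yet been measured. It differs from compound 3 in one place: 4-ethylbenzyl in place of 2,4-dimethoxyphenyl on an aromatic nitrogen. For the measured compounds named here, no measured pair differs by exactly this change, so the step from compound 1 to compound 2 does not bear on it directly; it concerns the amide side of the molecule, not the triazole nitrogen. Compound 1 already carries the 4-ethylbenzyl group and binds well, and compound 3 carries the pyridin-2-ylacetyl amide and binds well, so compound 4, which combines both, is expected to land near these two, with an expected step of a 1.3-fold lower number from compound 3 to compound 4 (0.12 log units; within the scatter). The estimate for compound 4 is 90 nM, expected to fall between 30 nM and 300 nM.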

Compound 4, half-maximal inhibitory concentration: 51 nM
The estimate for compound 4 lay 1.8-fold (0.25 log units) above the measured number; low and high end bracket the measured number.
By their numbers in this assay, from the lowest: compounds 4, 1 and 3 (each within the scatter of the next, the first and the last beyond it). At a limit, above all of these: compound 2.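

In this assay, with the amide side held fixed, 4-ethylbenzyl in place of 2,4-dimethoxyphenyl on the aromatic nitrogen gives a 2.4-fold lower number from compound 3 to compound 4 (0.37 log units; beyond the scatter), so this position responds to its substituent, and here a group made of carbon only serves at least as well as one carrying two methoxy oxygens. On the amide side, (pyridin-2-yl)methyl in place of pyridin-2-yl gives a 1.3-fold lower number from compound 1 to compound 4 (0.12 log units; within the scatter), so the two amides cannot be told apart when the 4-ethylbenzyl group is present. The step of an at least 19-fold lower number from compound 2 to compound 4 (1.29 log units; beyond the scatter) is only a bound, since the value for compound 2 is a limit and not a number: the limit of > 1000 nM in this assay, at which 1 of the 4 values shown sits.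

The swap on the nitrogen alters the ring's substituents and adds a methylene link in one move, so these compounds cannot show which of the two matters, and a plain benzyl or a 2,4-dimethoxybenzyl group would be needed to separate them. As far as these compounds go, how a pyridin-3-yl amide, with its ring nitrogen in the remaining position, would fare also stays open.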